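The source may report more compounds than this note shows. Statements on the series, on what has been measured and on what is new or still open speak of the compounds shown alone.

Among the measured compounds shown here, in a functional assay on HCT-116 cells (Homo sapiens) for inhibition, read by MTT assay, with a stated time of 2 days, tested at 10 uM (a higher number here means more inhibition of growth at the concentration tested, a lower number less inhibition of growth), compound 2 `CNC(=O)c1cc(Oc2ccc3nc(NC(=O)Nc4ccc(Br)cc4)sc3c2)ccn1` gives 12.1%, and it is one of only two compounds with a number here; the other, compound 1 `CNC(=O)c1cc(Oc2ccc3nc(NC(=O)c4cccc(F)n4)sc3c2)ccn1`, gives 10.8%, and the two sit within the scatter of each other. Both share the same core, and they differ only in the group attached to the carbonyl carbon of the side chain. The measured step between them, a number 1.3 percentage points higher from compound 1 to compound 2 (within the scatter), exchanged that whole group and still changed nothing beyond the scatter, which is all the comparison there is so far.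

Compound 3 `CNC(=O)c1cc(Oc2ccc3nc(NC(=O)Nc4ccc(Cl)cc4Cl)sc3c2)ccn1` carries a smaller change: 2,4-dichlorophenyl in place of 4-bromophenyl on an amide-type nitrogen. Here the urea arrangement of compound 2 stays, and only the halogen pattern on the phenyl ring is altered. For the measured compounds named here, the single known step bears on this only loosely, since it involved a larger swap and was itself within the scatter, so no step beyond the scatter is expected in this assay either. Compound 3 is therefore estimated at 14%, within a range of 2% to 30%, which means an expected a number 1.9 percentage points higher from compound 2 to compound 3 (within the scatter).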

Compound 3, percent growth inhibition at one concentration: 32.2%
Beside the measured number, compound 3's estimate is 18.2 percentage points below it; the measured number lies above the stated range.
By their numbers in this assay, from the lowest: compounds 1 and 2 (each within the scatter of the next); then compound 3.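

Compound 2 and compound 3 keep the same urea arrangement and differ only on the amide-type nitrogen, yet putting 2,4-dichlorophenyl in place of 4-bromophenyl gives a number 20.1 percentage points higher from compound 2 to compound 3 (beyond the scatter) in this assay. This shows that the substituents on this phenyl ring can move the result, even though both groups keep one six-membered aromatic ring of carbon only and neither carries a hydrogen-bond donor or acceptor. Exchanging the 6-fluoropyridin-2-yl group on the carbonyl carbon for (2,4-dichlorophenyl)amino gives a number 21.4 percentage points higher from compound 1 to compound 3 (beyond the scatter), whereas compound 2 stayed within the scatter of compound 1, so a phenylamino group there is not enough by itself, and nothing measured here gives a reason for the rise.

This change removes a bromine and adds two chlorines in one step, so the compounds shown cannot separate the effect of the second halogen from that of the change of element; 4-chlorophenyl and 2-chlorophenyl would pull these apart. As far as these compounds go, whether halogens are needed at all also stays open, since 4-methoxyphenyl or 4-methylphenyl at this position would test a ring carrying no halogen.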